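A few compounds are considered here, and "the series" means these few. Any claim that something is new, unique, unknown or untested is made for them only; others in the source may bear on it.

In a functional assay on SK-N-SH cells (Homo sapiens) for cytotoxicity, read by MTT assay, with a stated time of 24 h (a lower number here means a stronger inhibitor, a higher number a weaker inhibitor), three compounds with a shared core have been measured: compound 1 `COc1cc(/C=C(\C#N)C(=O)N/N=C(\C)c2c(O)c3ccc(O)cc3oc2=O)ccc1O` at 14400 nM and compound 2 `C/C(=N\NC(=O)/C(C#N)=C/c1ccc(Br)cc1)c1c(O)c2ccc(O)cc2oc1=O` at 12100 nM and compound 3 `C/C(=N\NC(=O)/C(C#N)=C/c1ccc([N+](=O)[O-])cc1)c1c(O)c2ccc(O)cc2oc1=O` at 10300 nM in the same test. Compound 3 stands level with the other two, as the three measured steps show: a 1.4-fold lower number from compound 1 to compound 3 (0.15 log units; within the scatter) and a 1.2-fold lower number from compound 2 to compound 3 (0.07 log units; within the scatter) and a 1.2-fold lower number from compound 1 to compound 2 (0.08 log units; within the scatter) in this small set. Compound 4 `C/C(=N\NC(=O)/C(C#N)=C/c1cccc(Br)c1)c1c(O)c2ccc(O)cc2oc1=O` keeps the core of compound 3 and carries 3-bromophenyl in place of 4-nitrophenyl (3-bromophenyl in place of 4-nitrophenyl on a double-bonded chain carbon bound to a double-bonded chain carbon). All three steps bear on this change. Each swaps the group at this same place, and the closest is a 1.2-fold lower number from compound 2 to compound 3 (0.07 log units; within the scatter) for an exchange of bromo and nitro. Among the measured compounds shown here, no measured compound carries 3-bromophenyl, so that arrangement remains untested. No step beyond the scatter is therefore expected in this assay for this change. The expected change is small and its direction uncertain: a 1.2-fold higher number from compound 3 to compound 4 (0.07 log units; within the scatter) is the estimated step. Compound 4 is estimated at 12000 nM with an expected range from 7000 nM to 20000 nM in this test.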

Compound 4, half-maximal inhibitory concentration: 31300 nM
The estimate for compound 4 lay 2.6-fold (0.42 log units) below the measured number; measured number outside the range, above it.
By their numbers in this assay, from the lowest: compounds 3, 2 and 1 (each within the scatter of the next); then compound 4.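

The group at this place is not indifferent after all: 3-bromophenyl in place of 4-bromophenyl gives a 2.6-fold higher number from compound 2 to compound 4 (0.41 log units; beyond the scatter) in this assay, so the same bromo on a different ring carbon changes the result, while the three earlier groups stood within the scatter of one another. Compound 4 is also the weakest of the four, with the other two steps reading a 3.0-fold higher number from compound 3 to compound 4 (0.48 log units; beyond the scatter) and a 2.2-fold higher number from compound 1 to compound 4 (0.34 log units; beyond the scatter). Compound 1 goes against any simple rule about the ring, as its 4-hydroxy-3-methoxyphenyl also carries a group at the 3-position of the ring, and nothing shown accounts for the rise.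

As far as these compounds go, whether the loss belongs to bromo alone or to any group in this arrangement remains open. A 3-aminophenyl or 3-methylphenyl group at this place would help to separate the two.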